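The source may report more compounds than this note shows. Statements on the series, on what has been measured and on what is new or still open speak of the compounds shown alone.

Working notes on the series. Going by the values given here, compound 1 `COc1cc(/C=C/C(=O)c2cccc(-n3cc(-c4ccccc4)[nH]c3=O)c2)ccc1O` is the only member with a number: in a functional assay on TK-10 cells (Homo sapiens) for inhibition (a lower number here means a stronger inhibitor of growth, a higher number a weaker inhibitor of growth), compound 1 gives 5290 nM. Compound 2 `O=C(/C=C/c1cccc(O)c1)c1cccc(-n2cc(-c3ccccc3)[nH]c2=O)c1` shares the core but carries a hydroxyl on the cinnamoyl ring in place of the methoxy-hydroxy pair; for compound 2 the result in this assay reads "not determined" (no result reported), so compound 2 stands without a number. Compound 3 `O=C(/C=C/c1cccc(O)c1)c1cccc(-n2cc(-c3ccc(Cl)cc3)[nH]c2=O)c1` differs from compound 2 by chloro in place of hydrogen on an aromatic carbon. Among the compounds with values here, with no measured step on the chloro change, any shift in this assay is expected to stay within the scatter, in no firm direction. For compound 3 the expected value in this assay is 4500 nM, in the range 1200 nM to 16000 nM.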

Compound 3, concentration for 50% growth inhibition: 2830 nM
Beside the measured number, compound 3's estimate is 1.6-fold (0.20 log units) above it; the measured number falls inside the stated range.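

Compound 2 has no number in this assay, and the chloro step to compound 3 cannot be read. No evidence shown bears on the value of compound 3.

From the compounds shown here alone, the size and direction of the change from phenyl to 4-chlorophenyl remain open.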